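This account rests on a few compounds, and the source may have more. Where it says the series, first, only, none or still open, it means among the compounds named here.

Of the compounds shown here, three built on related cores have been tested in an ADME assay on cells (Rhabdomyosarcoma cell, Homo sapiens) for cytotoxicity, read by MTT assay, with a stated time of 72 h; a higher number here means that more compound is tolerated, a lower number that less compound is tolerated. Compound 1 (`Nc1sc2c(c1-c1nc3cc(Cl)ccc3s1)CCC2`) gives 59.1 ug/mL, compound 2 (`Clc1ccc(/C=N/c2sc3c(c2-c2nc4ccccc4s2)CCC3)c(Cl)c1`) gives 160 ug/mL, and compound 3 (`Fc1ccc(/C=N/c2sc3c(c2-c2nc4ccccc4s2)CCCC3)cc1`) gives 230 ug/mL. Compound 3 and compound 2 lie within the scatter of each other, whereas compound 1 stands lower than compound 3 by a gap beyond the scatter.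

Compound 4 (`FC(F)(F)c1ccc(/C=N/c2sc3c(c2-c2nc4ccccc4s2)CCCC3)cc1`) has trifluoromethyl in place of fluoro on an aromatic carbon of compound 3, para to a large group: trifluoromethyl in place of fluoro on an aromatic carbon. Within the data shown here, no measured pair shows this change, so the data give no direct size for it. Compound 2 at 160 ug/mL differs from compound 3 in more than one place and still stays within the scatter of it, so no step beyond the scatter is expected here. The expected step, a 1.2-fold lower number from compound 3 to compound 4 (0.08 log units; within the scatter), is small and slightly downward. Compound 4 is estimated at 190 ug/mL, with an expected range of 90 ug/mL to 400 ug/mL.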

Compound 4, half-maximal cytotoxic concentration: 250 ug/mL
The estimate for compound 4 lay 1.3-fold (0.12 log units) below the measured number; the range from low to high includes it.
By their numbers in this assay, from the lowest: compound 1; then compounds 2, 3 and 4 (each within the scatter of the next).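

In this assay the replacement of fluoro by trifluoromethyl on an aromatic carbon, para to a large group, gives a 1.1-fold higher number from compound 3 to compound 4 (0.04 log units; within the scatter) and so provides the first direct measure of a single change in this set. The larger group, with 4 heavy atoms in place of 1, therefore leaves the number within the scatter, at least for 4-fluorophenyl to 4-(trifluoromethyl)phenyl on the core of compound 3. No measurement shown here offers an explanation for this result.

From the compounds shown here alone, whether an amine or a carboxylic acid on the same aromatic carbon would also leave the number within the scatter remains open. It is also unresolved whether the same replacement would behave alike on the core of compound 2, and what sets compound 1 apart, since it differs from the others in more than one place.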